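Fluorobenzyl pattern in the shared core series

The compounds below may be only part of what the source reports. "The series", "measured", "known", "first", "only" and "open" are said of these compounds alone.

compound 1 `O=C(Nc1ccc(-c2cscn2)cc1)C1CCCN(Cc2ccc(F)c(F)c2)C1` | 1240 nM
compound 2 `O=C(Nc1ccc(-c2cscn2)cc1)C1CCCN(Cc2cccc(F)c2F)C1` | 10000 nM

In a functional assay on A-375 cells (Homo sapiens) for activation, with a stated time of 3 days (on this read-out higher numbers stand for an effect only at larger amounts of compound and lower numbers for an effect already at smaller amounts), compound 2 stands highest of the two numbers. Compound 3 `O=C(Nc1ccc(-c2cscn2)cc1)C1CCCN(Cc2cc(F)c(F)c(F)c2)C1` follows from 3,4,5-trifluorophenyl in place of 2,3-difluorophenyl on a saturated chain carbon bound to an amine nitrogen in a ring with 3,4,5-trifluorophenyl in place of 2,3-difluorophenyl on a saturated chain carbon bound to an amine nitrogen in a ring. Going by the values given here, only one measured step bears on this change: an 8.1-fold higher number from compound 1 to compound 2 (0.91 log units; beyond the scatter) on replacing 3,4-difluorophenyl with 2,3-difluorophenyl, beyond the scatter. A step of similar size towards lower numbers is therefore expected, though one step is thin evidence. For compound 3 the expected change is a 6.7-fold lower number from compound 2 to compound 3 (0.82 log units; beyond the scatter) in this assay on this reasoning. Compound 3 is estimated at 1500 nM with an expected range of 500 nM to 5000 nM for now.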

Compound 3, half-maximal effective concentration: 1260 nM
Compound 3: middle estimate off by 1.2-fold (0.08 log units), on the high side, within the range that was stated.
By their numbers in this assay, from the lowest: compounds 1 and 3 (each within the scatter of the next); then compound 2.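

In this assay, 3,4,5-trifluorophenyl restores what 2,3-difluorophenyl lacks at this place, with a 7.9-fold lower number from compound 2 to compound 3 (0.90 log units; beyond the scatter) and so a second step beyond the scatter around compound 2. Fluoro in place of hydrogen on an aromatic carbon of compound 1 gives a 1.0-fold higher number from compound 1 to compound 3 (0.01 log units; within the scatter), so among these three only compound 2 stands apart. Nothing available accounts for either step.

Open, going by these compounds, is how a plain phenyl or a pyridine ring would read on this saturated chain carbon bound to an amine nitrogen in a ring. Also open, on these data alone, is whether a chlorophenyl would follow compound 1 and compound 3 or compound 2.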